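A methoxy swap on a compound at the limit

This account rests on a few compounds, and the source may have more. Where it says the series, first, only, none or still open, it means among the compounds named here.

Compound 1 (`C=CCOc1ccc(-c2ccc(OC)cc2)cc1CC=C`) > 100000 nM
Compound 2 (`C=CCc1cc(-c2ccc(F)cc2)ccc1O`) > 100000 nM

In a functional assay on A549 cells (Homo sapiens) for antiproliferative activity, read by MTT assay, with a stated time of 24 h (a lower number here means a stronger inhibitor, a higher number a weaker inhibitor), compound 2 gives > 100000 nM as a limit of the assay, not a number. Compound 1 gives > 100000 nM there, also a limit. Going by the values given here, both compounds therefore rest at the limit of > 100000 nM in this assay, at which 2 of the 2 values shown sit, and show no measured step. Compound 3 (`C=CCc1cc(-c2ccc(OC)cc2)ccc1O`) has methoxy in place of fluoro on an aromatic carbon, para to a large group (methoxy in place of fluoro on an aromatic carbon). Since compound 2 offers only the limit > 100000 nM as a starting point, at most a small move toward a lower number is expected in this assay and possibly none beyond the scatter. The estimated step of an at least 1.1-fold lower number from compound 2 to compound 3 (0.04 log units; that floor lies within the scatter) is small. In this assay compound 3 is expected at 90000 nM (estimated range 30000 nM to 200000 nM).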

Compound 3, half-maximal inhibitory concentration: > 100000 nM
Compound 3: no number, only a limit; the forecaster's own chance of this, stated with the estimate: 60%; at least 1.1-fold (0.04 log units) between middle value and limit.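

Compound 3 gives > 100000 nM in this assay, a limit of the assay and not a number, so no step to compound 1 or compound 2 can be read: the limit of > 100000 nM in this assay, at which 3 of the 3 values shown sit.

How strongly any of these compounds acts on the cells remains open.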